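Ring methyl and half-life in the sulfoxide series

This account rests on a few compounds, and the source may have more. Where it says the series, first, only, none or still open, it means among the compounds named here.

Compound 1, `COc1c(C)cnc(C[S+]([O-])c2nc3cc(OC(F)F)ccc3[nH]2)c1C`, gives 15 h in an ADME assay for pharmacokinetics, at pH 7.4; a lower number here means that the compound disappears faster, a higher number that the compound lasts longer.
Compound 2, `COc1ccnc(C[S+]([O-])c2nc3cc(OC(F)F)ccc3[nH]2)c1C`, gives 3 h in this assay.
Compound 3, `COc1cnc(C[S+]([O-])c2nc3cc(OC(F)(F)C(F)F)ccc3[nH]2)cc1OC`, gives 140 h in this assay.

Compound 3 stands highest of the three; its nearest neighbour is compound 1 and its furthest compound 2. Compounds 2 and 1 differ in one place only, marked (methyl in place of hydrogen on an aromatic carbon), and that change gives a 5.0-fold higher number from compound 2 to compound 1 (0.70 log units; beyond the scatter).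

Compound 4, `COc1cnc(C[S+]([O-])c2nc3cc(OC(F)(F)C(F)F)ccc3[nH]2)c(C)c1OC`, has not yet been measured in this assay. It differs from compound 3 by methyl in place of hydrogen on an aromatic carbon. This is the same kind of change as that from compound 2 to compound 1, but not the same: in compound 4 the methyl sits ortho to a large group and meta to a methoxy group, while in compound 1 it sits meta to a methyl group and para to a large group. How the core of compound 3 differs from the core of compound 2 is not broken down here; the values alone show a wide gap between them.

Among the measured compounds shown here, with a single precedent, the step of a 5.0-fold higher number from compound 2 to compound 1 (0.70 log units; beyond the scatter) is the only guide, and the place lines differ, so the step is expected to be smaller than that one. Compound 4 is therefore expected to show a 2.1-fold higher number from compound 3 to compound 4 (0.33 log units; beyond the scatter). Compound 4 is estimated at 300 h, with a range from 100 h to 900 h.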

Compound 4, half-life: 43 h
Compound 4: middle estimate off by 7.0-fold (0.84 log units), on the high side, and the stated range ends above it.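

In this assay, methyl in place of hydrogen on an aromatic carbon gives a 3.3-fold lower number from compound 3 to compound 4 (0.51 log units; beyond the scatter), so the direction seen on the first core does not hold on the second. Set side by side, the two steps point opposite ways and their gap is not a matter of repeat noise: the same change on two cores in this assay, a 5.0-fold higher number (0.70 log units; beyond the scatter) from compound 2 to compound 1 and a 3.3-fold lower number (0.51 log units; beyond the scatter) from compound 3 to compound 4, 16-fold (1.21 log units) apart, beyond the scatter of two such steps

For this series, the step on one core is therefore no reliable guide to the sign or size of the same change on the other. This does not show what drives the reversal, as there is one pair per core and the core and the place of the methyl differ together: in compound 4 the methyl is ortho to a large group and ortho to a methoxy group, a different setting from that in compound 1.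

The compounds shown leave open whether the core or the place decides the outcome, since neither is varied with the other held fixed. Also open, as far as these compounds go, is how ethyl or chlorine in that same place on the core of compound 3 would read, and whether either would follow the methyl step.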